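Cyclopropyl to butyl on the amide nitrogen

The source may report more compounds than this note shows. Statements on the series, on what has been measured and on what is new or still open speak of the compounds shown alone.

In a functional assay on A549 cells (Homo sapiens) for inhibition, read by sulforhodamine B assay, with a stated time of 72 h (on this read-out higher numbers stand for weaker inhibition and lower numbers for stronger inhibition), the measured compounds are:
Compound 1 `Nc1sc(-c2ccc(Cl)cc2)c(-c2ccc(Cl)cc2)c1C(=O)N1CCCC1`: 890 nM
Compound 2 `Nc1sc(-c2ccc(Cl)cc2)c(-c2ccc(Cl)cc2)c1C(=O)NC1CC1`: 1950 nM
Compound 3 `CS(=O)(=O)Nc1sc(-c2ccc(Cl)cc2)c(-c2ccc(Cl)cc2)c1C(=O)NC1CC1`: "not determined" (no result reported)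

Compound 2 gives the highest of the two numbers shown; its nearest neighbour is compound 1, with a 2.2-fold higher number from compound 1 to compound 2 (0.34 log units; beyond the scatter). Compound 4 `CCCCNC(=O)c1c(N)sc(-c2ccc(Cl)cc2)c1-c1ccc(Cl)cc1` differs from compound 2 by butyl in place of cyclopropyl on an amide-type nitrogen. Going by the values given here, the only measured step, a 2.2-fold higher number from compound 1 to compound 2 (0.34 log units; beyond the scatter), also alters the group on the carbonyl carbon, but it exchanges pyrrolidin-1-yl for cyclopropylamino, and no measured pair exchanges cyclopropyl for a chain. Compound 4 is therefore expected to show no step beyond the scatter, a 1.2-fold lower number from compound 2 to compound 4 (0.09 log units; within the scatter). Compound 4 is estimated at 1600 nM, in a range from 600 nM to 4500 nM.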

Compound 4, half-maximal inhibitory concentration: 8170 nM
Compound 4: middle estimate off by 5.1-fold (0.71 log units), on the low side; the measured number lies above the stated range.
By their numbers in this assay, from the lowest: compound 1; then compound 2; then compound 4.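

The amide nitrogen does not treat cyclopropyl and butyl alike: the change to the open chain gives a 4.2-fold higher number from compound 2 to compound 4 (0.62 log units; beyond the scatter), a larger step than the one between the two ring-bearing groups. Against pyrrolidin-1-yl, butylamino on the carbonyl carbon gives a 9.2-fold higher number from compound 1 to compound 4 (0.96 log units; beyond the scatter), so among these three compounds, butylamino gives the weakest inhibition. Nothing shown here explains this difference. On these data alone, whether ethyl, isopropyl or cyclobutyl on the amide nitrogen would stay nearer compound 2 or compound 4 remains open. So does whether the cyclopropyl finding holds with a methanesulfonamide in place of the free amine.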